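This account rests on a few compounds, and the source may have more. Where it says the series, first, only, none or still open, it means among the compounds named here.

Measured in a functional assay on HeLa cells (Homo sapiens) for antiproliferative activity, read by MTT assay, with a stated time of 48 h; on this read-out higher numbers stand for weaker inhibition and lower numbers for stronger inhibition:

- Compound 1 `Cn1cc(-c2cnc3ccc(NS(=O)(=O)c4ccc(C(F)(F)F)cc4)nc3c2)cn1`: > 50000 nM (a limit, not a number)
- Compound 2 `Cn1cc(-c2cnc3ccc(NS(=O)(=O)c4cccs4)nc3c2)cn1`: 38400 nM

Among the measured compounds shown here, compound 2 holds the only true number in this assay, so it has no measured neighbour against which it can be ranked firmly. The other result is a limit: the limit of > 50000 nM in this assay, at which 1 of the 2 values shown sits.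

The next compound, compound 3 `Cn1cc(-c2cnc3ccc(NS(=O)(=O)c4ccc(Cl)cc4Cl)nc3c2)cn1`, has 2,4-dichlorophenyl in place of thiophen-2-yl on a sulfonyl sulfur. For the measured compounds named here, only one measured step bears on this change, and it concerns the same place: an at least 1.3-fold lower number from compound 1 to compound 2 (0.11 log units; that floor lies within the scatter). That step exchanged a substituted six-membered aromatic ring for thiophen-2-yl, and compound 3 now carries a different substituted six-membered aromatic ring in that place. The measured step is small and gives only a floor, so it offers little support for a firm direction. A slightly weaker result than that of compound 2 is conceivable, but the expectation is for no change beyond the scatter. The expected step is a 1.1-fold lower number from compound 2 to compound 3 (0.04 log units; within the scatter). For compound 3 the estimated value is 35000 nM, with an expected range of 12000 nM to 70000 nM.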

Compound 3, half-maximal inhibitory concentration: > 50000 nM
Compound 3 ended at the assay's limit; the forecaster's own chance of this, stated with the estimate: 35%; middle value at least 1.4-fold (0.15 log units) from the limit.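

In this assay compound 3 gives > 50000 nM, which is a limit of the assay and not a number. Exchanging thiophen-2-yl for 2,4-dichlorophenyl on the sulfonyl sulfur gives an at least 1.3-fold higher number from compound 2 to compound 3 (0.11 log units; that floor lies within the scatter), so this change brings no readable gain in this assay, and the size of any loss cannot be told beyond a floor that stays within the usual scatter. The step between the two substituted six-membered aromatic rings of compound 1 and compound 3 cannot be read, and what this result adds is that a second such ring in this place also ends at the limit rather than at a number: the limit of > 50000 nM in this assay, at which 2 of the 3 values shown sit.

Among the compounds shown here, compound 2 therefore remains the only compound with a true number, and whether thiophen-2-yl truly differs from either six-membered ring stays unresolved. Also open, going by these compounds, is how this sulfonyl place would respond to a group of another kind, such as an aliphatic amine or a carboxylic acid on the ring, and whether any group here could bring the read-out well clear of the limit.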